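This account rests on a few compounds, and the source may have more. Where it says the series, first, only, none or still open, it means among the compounds named here.

Two compounds share a core built on a cyclic ketone that carries two benzylidene arms and an amide-bearing side chain. Compound 1, `O=C1/C(=C/c2ccc(Cl)cc2)CN(C(=O)CCSCCS(=O)(=O)O)C/C1=C\c1ccc(Cl)cc1`, pairs chloro arms with a sulfo-terminated chain; compound 2, `O=C1/C(=C/c2ccc([N+](=O)[O-])cc2)CN(C(=O)CCSCCO)C/C1=C\c1ccc([N+](=O)[O-])cc1`, pairs nitro arms with a hydroxy-terminated chain. In a functional assay on HL-60 cells (Homo sapiens) for cytotoxicity, read by trypan blue exclusion, with a stated time of 48 h (a higher number here means that more compound is tolerated, a lower number that less compound is tolerated), compound 1 gives 29700 nM, while compound 2 gives 390 nM, the lower of the two numbers, and the gap between them lies well beyond the scatter. The two differ in two places at once. No single-change step can be read from them.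

Compound 3, `O=C1/C(=C/c2ccc([N+](=O)[O-])cc2)CN(C(=O)CCSCCS(=O)(=O)O)C/C1=C\c1ccc([N+](=O)[O-])cc1`, keeps the nitro arms of compound 2 and alters only the chain end: sulfo in place of hydroxy on a saturated chain carbon, two bonds along the chain from a sulfur. Within the data shown here, no measured pair shows this change on its own. Given only that the sole sulfo compound on record, compound 1, sits at 29700 nM, a rise in the number is expected, of modest size, as a 3.8-fold higher number from compound 2 to compound 3 (0.59 log units; beyond the scatter). Compound 3 is therefore estimated at 1500 nM, within a range of 400 nM to 8000 nM.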

Compound 3, half-maximal cytotoxic concentration: 4730 nM
Compound 3: middle estimate off by 3.2-fold (0.50 log units), on the low side; the range from low to high includes it.
By their numbers in this assay, from the lowest: compound 2; then compound 3; then compound 1.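

Among these compounds, compound 3 isolates the chain end for the first time: with the nitro arms unchanged, sulfo in place of hydroxy on a saturated chain carbon, two bonds along the chain from a sulfur, produces a large change in this assay (a 12-fold higher number from compound 2 to compound 3 (1.08 log units; beyond the scatter)). This position is therefore sensitive to the group it carries, and here the switch from hydroxy to sulfo means that more compound is tolerated. The sulfo group does not set one fixed number, however: with chloro arms, compound 1 stands at (29700 nM), whereas with nitro arms, compound 3 stands at (4730 nM).

From the compounds shown here alone, it remains open whether a carboxylic acid or an amine at the same chain end, or a longer chain carrying sulfo, would shift the number in the same way. No measurement shown here explains why this change moves the number.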